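Benzyl aryl change on the shared core

The source may hold more compounds than are shown below. What is called first, only, known or untested is meant among the compounds shown, and "the series" means these compounds.

Compound 2 `Cc1cccc(Cn2c(=O)oc3cc(-c4cnc5[nH]ccc5c4)ccc32)c1` gives 5120 nM in a functional assay on HCT-116 cells (Homo sapiens) for inhibition, read by MTT assay, with a stated time of 72 h; a higher number here means a weaker inhibitor, a lower number a stronger inhibitor. Compound 1 `O=c1oc2cc(-c3cnc4[nH]ccc4c3)ccc2n1Cc1cccc(F)c1` gives 5920 nM in this assay, and the step of a 1.2-fold lower number from compound 1 to compound 2 (0.06 log units; within the scatter) is within the scatter, so compound 2 stands level with compound 1 rather than apart from it. Compound 3 `COc1cc(Cn2c(=O)oc3cc(-c4cnc5[nH]ccc5c4)ccc32)ccc1F` differs from compound 2 by 4-fluoro-3-methoxyphenyl in place of 3-methylphenyl on a saturated chain carbon bound to an aromatic nitrogen. Among the compounds with values here, the only measured step touching this position is the one from compound 1 to compound 2, and it stayed within the scatter; a similar outcome is expected here, with a 1.1-fold higher number from compound 2 to compound 3 (0.03 log units; within the scatter) as the estimated shift. Compound 3 is expected to give 5500 nM, in the range 2500 nM to 12000 nM.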

Compound 3, half-maximal inhibitory concentration: 8050 nM
The estimate for compound 3 lay 1.5-fold (0.17 log units) below the measured number; the measured number falls inside the stated range.
By their numbers in this assay, from the lowest: compounds 2, 1 and 3 (each within the scatter of the next).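

In this assay the step to 4-fluoro-3-methoxyphenyl reads as a 1.6-fold higher number from compound 2 to compound 3 (0.20 log units; within the scatter) and as a 1.4-fold higher number from compound 1 to compound 3 (0.13 log units; within the scatter). On a saturated chain carbon bound to an aromatic nitrogen, an aryl group with 9 heavy atoms and 1 hydrogen-bond acceptor therefore stays level with both earlier compounds, which the exchange of fluoro for methyl alone could not show. No supporting data bear on this result.

As far as these compounds go, whether an amine, a carboxylic acid or a longer chain in this place would give a step beyond the scatter remains open.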